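The source may report more compounds than this note shows. Statements on the series, on what has been measured and on what is new or still open speak of the compounds shown alone.

Compound 1, `CCS(=O)(=O)Nc1cc(-c2ccc3ncnc(Nc4ccc(F)cc4)c3c2)cnc1OC`, gives 3120 nM in a functional assay on BT-549 cells (Homo sapiens) for cytotoxicity, read by sulforhodamine B assay, with a stated time of 72 h; a higher number here means a weaker inhibitor, a lower number a stronger inhibitor.
Compound 2, `CCS(=O)(=O)Nc1cc(-c2ccc3ncnc(Nc4ccc(OC)cc4)c3c2)cnc1OC`, gives 1880 nM in this assay.
Compound 3, `CCS(=O)(=O)Nc1cc(-c2ccc3ncnc(Nc4ccc(F)nc4)c3c2)cnc1OC`, gives 4780 nM in this assay.

Compound 4, `CCS(=O)(=O)Nc1cc(-c2ccc3ncnc(Nc4ccc(OC)nc4)c3c2)cnc1OC`, has not yet been measured in this assay. It differs from compound 3 by methoxy in place of fluoro on an aromatic carbon. The same change is present between compound 1 and compound 2, where it gave a 1.7-fold lower number from compound 1 to compound 2 (0.22 log units; within the scatter), a step that is too small to count as a real shift. The two cores are not identical: compound 3 departs from compound 1 by 6-fluoropyridin-3-yl in place of 4-fluorophenyl on a nitrogen on an aromatic ring, and the surroundings of the change differ in kind as well. In compound 1 the exchange sits on a six-membered aromatic ring of carbon only, para to a large group; in compound 3 it sits on a six-membered aromatic ring with 1 nitrogen, next to the ring nitrogen, para to a large group. It is therefore the same kind of change, not the same change. The size of the step from compound 3 to compound 4 is expected to be a 1.6-fold lower number from compound 3 to compound 4 (0.22 log units; within the scatter), because the earlier instance gave only a 1.7-fold lower number from compound 1 to compound 2 (0.22 log units; within the scatter) and the core difference offers no reason to expect more. Compound 4 is estimated at 2900 nM, with a likely range from 1400 nM to 6000 nM.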

Compound 4, half-maximal inhibitory concentration: 3490 nM
Beside the measured number, compound 4's estimate is 1.2-fold (0.08 log units) below it; measured number inside the range.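

In this assay, methoxy in place of fluoro on the six-membered aromatic ring with 1 nitrogen gives a 1.4-fold lower number from compound 3 to compound 4 (0.14 log units; within the scatter), and this step does not differ from the earlier one on the core of compound 1: the same change on two cores in this assay, a 1.7-fold lower number (0.22 log units; within the scatter) from compound 1 to compound 2 and a 1.4-fold lower number (0.14 log units; within the scatter) from compound 3 to compound 4, 1.2-fold (0.08 log units) apart, within the scatter of two such steps. The other two steps to compound 4 are also small, with 6-methoxypyridin-3-yl in place of 4-methoxyphenyl giving a 1.9-fold higher number from compound 2 to compound 4 (0.27 log units; within the scatter) and in place of 4-fluorophenyl giving a 1.1-fold higher number from compound 1 to compound 4 (0.05 log units; within the scatter). The pairs therefore show that the change carries across these two cores as a step within the scatter on each, but they do not show that it has a real effect on either core, and two pairs set no rule for other cores.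

The compounds shown leave open whether an amine, a hydroxyl or a longer chain such as ethoxy at this same place would give a step beyond the scatter. On these data alone, it also remains open whether a carboxylic acid or a morpholine elsewhere on the shared core would do so.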